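From 4-bromophenyl to 3-bromophenyl

A few compounds are considered here, and "the series" means these few. Any claim that something is new, unique, unknown or untested is made for them only; others in the source may bear on it.

In a functional assay on MCF7 cells (Homo sapiens) for cytotoxicity, read by MTT assay, with a stated time of 24 h (a lower number here means a stronger inhibitor, a higher number a weaker inhibitor), compound 1 (`C/C(=N\NC(=O)/C(C#N)=C/c1ccccc1)c1c(O)c2ccc(O)cc2oc1=O`) gives 19200 nM and compound 2 (`C/C(=N\NC(=O)/C(C#N)=C/c1ccc(Br)cc1)c1c(O)c2ccc(O)cc2oc1=O`) gives 9850 nM. Among the compounds with values here, compound 2 thus stands within the scatter of compound 1, with a 1.9-fold lower number from compound 1 to compound 2 (0.29 log units; within the scatter) as the only measured step, bromo in place of hydrogen on an aromatic carbon. Compound 3 (`C/C(=N\NC(=O)/C(C#N)=C/c1cccc(Br)c1)c1c(O)c2ccc(O)cc2oc1=O`) has the same atoms joined differently: 3-bromophenyl in place of 4-bromophenyl on a double-bonded chain carbon bound to a double-bonded chain carbon. Within the data shown here, no measured step moves the bromine, so that single step bears on this change only indirectly, and no shift beyond the scatter is expected in this assay. The estimated step is a 1.1-fold higher number from compound 2 to compound 3 (0.05 log units; within the scatter). Compound 3 is expected at 11000 nM, within an estimated range of 5000 nM to 23000 nM.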

Compound 3, half-maximal inhibitory concentration: 19600 nM
The estimate for compound 3 lay 1.8-fold (0.25 log units) below the measured number, within the range that was stated.
By their numbers in this assay, from the lowest: compounds 2, 1 and 3 (each within the scatter of the next).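

In this assay the shift of the bromine gives a 2.0-fold higher number from compound 2 to compound 3 (0.30 log units; within the scatter) and the bromo replacement of hydrogen gives a 1.0-fold higher number from compound 1 to compound 3 (0.01 log units; within the scatter) so both steps lie within the scatter. This assay therefore does not separate 3-bromophenyl from 4-bromophenyl at this place, nor either of them from the phenyl of compound 1. No evidence on the cause of these numbers is available. Going by these compounds, whether an amine or a carboxylic acid on this ring would give a step beyond the scatter remains open.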